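A few compounds are considered here, and "the series" means these few. Any claim that something is new, unique, unknown or untested is made for them only; others in the source may bear on it.

Values in a physicochemical assay for permeability, using PAMPA; on this read-out higher numbers stand for higher permeability and lower numbers for lower permeability:
- compound 1 `C[C@@H](Oc1cc2oc(=O)n(CCC(=O)O)c2cc1Cl)c1ccc(F)cn1`: 31 nm/s
- compound 2 `C[C@@H](Oc1cc2oc(=O)n(CCC(=O)O)c2cc1Cl)c1ccc(Cl)cn1`: 60 nm/s
- compound 3 `C[C@@H](Oc1cc2oc(=O)n(CCC(=O)O)c2cc1Cl)c1ncco1`: < 3 nm/s (a limit of the assay, not a number)

Compound 3 stands lowest of the three, at the limit of < 3 nm/s in this assay, at which 1 of the 3 values shown sits. The next compound to be measured, compound 4 `Cc1cccc([C@@H](C)Oc2cc3oc(=O)n(CCC(=O)O)c3cc2Cl)n1`, differs from it in one place, with 6-methylpyridin-2-yl in place of 1,3-oxazol-2-yl on a saturated chain carbon bound to an oxygen on an aromatic ring and a saturated chain carbon.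

Within the data shown here, two measured steps bear on this change, and both are large and beyond the scatter: an at least 10-fold lower number from compound 1 to compound 3 (1.01 log units; beyond the scatter), and an at least 20-fold lower number from compound 2 to compound 3 (1.30 log units; beyond the scatter). Each of them puts in the 1,3-oxazol-2-yl group that compound 4 gives up, so the change to compound 4 runs the opposite way. The exchange between the two pyridine groups already measured gives a 1.9-fold higher number from compound 1 to compound 2 (0.29 log units; within the scatter), which lies within the scatter. However, no measured compound carries the 6-methylpyridin-2-yl group, so the reversal may not be complete. A large rise in this assay is therefore expected, and the expected step is an at least 13-fold higher number from compound 3 to compound 4 (1.12 log units; beyond the scatter). Compound 4 is estimated at 40 nm/s, with an expected range from 12 nm/s to 120 nm/s.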

Compound 4, apparent permeability: 21 nm/s
Compound 4: the middle estimate sits 1.9-fold (0.28 log units) above what was measured; low and high end bracket the measured number.
By their numbers in this assay, from the lowest: compounds 4, 1 and 2 (each within the scatter of the next, the first and the last beyond it). At a limit, below all of these: compound 3.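

In this assay, the 6-methylpyridin-2-yl group shows that the rise away from the 1,3-oxazol-2-yl group at this saturated chain carbon is not confined to the two halogen-bearing pyridine groups: an at least 7.0-fold higher number from compound 3 to compound 4 (0.84 log units; beyond the scatter). The three pyridine groups do not all stand level, since the comparison with the chloro-bearing group gives a 2.9-fold lower number from compound 2 to compound 4 (0.46 log units; beyond the scatter), while the comparison with the fluoro-bearing group gives a 1.5-fold lower number from compound 1 to compound 4 (0.17 log units; within the scatter), so only the first of these two exchanges separates the compounds. The value of compound 3 remains a limit and not a number, so the rise from it is known only as a bound: the limit of < 3 nm/s in this assay, at which 1 of the 4 values shown sits.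

The compounds shown leave open whether a plain phenyl or a thiazol-2-yl group at this place would stand with the pyridine groups or with the 1,3-oxazol-2-yl group. Going by these compounds, all four also carry the same carboxylic acid chain on the shared core, so it remains open how these exchanges would read with an ester or an amide in place of the carboxylic acid.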